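The source may report more compounds than this note shows. Statements on the series, on what has been measured and on what is new or still open speak of the compounds shown alone.

In an ADME assay on microsomes from liver (Homo sapiens) for metabolic stability, tested at 2.5 uM (a higher number here means faster removal of the compound, a lower number slower removal), compound 1 `COc1cccc(-c2c(S(=O)(=O)c3ccc(OC)c(Cl)c3)cnc3cc(F)ccc23)c1` gives 1.71 mL/min. Compound 3 `COc1cccc(-c2c(S(=O)(=O)c3cccc(C#N)c3)cnc3cc(F)ccc23)c1` gives 1.83 mL/min, and compound 2 `COc1cccc(-c2c(S(=O)(=O)c3ccc(C)c(C)c3)cnc3cc(F)ccc23)c1` gives 8.78 mL/min, the highest of the three numbers; the steps of a 5.1-fold higher number from compound 1 to compound 2 (0.71 log units; beyond the scatter) and a 4.8-fold lower number from compound 2 to compound 3 (0.68 log units; beyond the scatter) are beyond the scatter, while a 1.1-fold higher number from compound 1 to compound 3 (0.03 log units; within the scatter) is within it. Compound 4 `Cc1ccc(S(=O)(=O)c2cnc3cc(F)ccc3c2-c2cccc(Cl)c2)cc1C` keeps the 3,4-dimethylphenyl of compound 2 on the sulfonyl sulfur and differs elsewhere: chloro in place of methoxy on an aromatic carbon. None of the three measured steps touches this part of the molecule; each of them changes only the group on the sulfonyl sulfur, so they give no direct guide to the size or direction of the new step. The step of a 1.3-fold lower number from compound 2 to compound 4 (0.10 log units; within the scatter) is therefore expected to remain within the scatter. The estimate for compound 4 in this assay is 7 mL/min, with a range from 3 mL/min to 16 mL/min.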

Compound 4, intrinsic clearance in a liver preparation (reported as CLH), per the amount of preparation that the assay uses: 4.01 mL/min
Beside the measured number, compound 4's estimate is 1.7-fold (0.24 log units) above it; the measured number falls inside the stated range.
By their numbers in this assay, from the lowest: compounds 1 and 3 (each within the scatter of the next); then compound 4; then compound 2.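

In this assay, among these compounds, chloro in place of methoxy, turning 3-methoxyphenyl into 3-chlorophenyl, gives a 2.2-fold lower number from compound 2 to compound 4 (0.34 log units; beyond the scatter) and so shows that this position, untouched by the earlier steps, can also move the number beyond the scatter, though only modestly. This holds so far only with the 3,4-dimethylphenyl group on the sulfonyl sulfur. Nothing available explains the step. The compounds shown leave open whether the same change behaves alike with 3-cyanophenyl or 3-chloro-4-methoxyphenyl on that sulfur, and how an amine or a fluoro group would read at this position.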